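The source may report more compounds than this note shows. Statements on the series, on what has been measured and on what is new or still open speak of the compounds shown alone.

Values in an ADME assay on Akata cells (Homo sapiens) for cytotoxicity, with a stated time of 7 days; on this read-out higher numbers stand for lower toxicity in this test and lower numbers for higher toxicity in this test:
- Compound 1 `CNc1nc(N)nc2c1ncn2/C=C1/CC1(CO)CO`: > 24000 nM, a limit
- Compound 2 `CN(C)c1nc(N)nc2c1ncn2/C=C1/CC1(CO)CO`: > 24000 nM, a limit
- Compound 3 `CC(C)Sc1nc(N)nc2c1ncn2/C=C1/CC1(CO)CO`: > 20000 nM, a limit

None of these three results is an exact number, so compound 3 stands only at its limit. Compound 4 `Nc1nc(SC2CCCC2)c2ncn(/C=C3/CC3(CO)CO)c2n1` keeps the shared core and changes one group: cyclopentyl in place of isopropyl on a sulfur. The closest measured steps are a step that the two limits leave unreadable from compound 1 to compound 3 and a step that the two limits leave unreadable from compound 2 to compound 3, both of which change the group at this place, and neither has a readable size. They offer no measured size to carry over, so no change beyond the scatter is expected in this assay. The estimated step is a number no higher from compound 3 to compound 4 (the limit leaves the size open). Compound 4 is estimated at 20000 nM. Its expected range runs from 10000 nM to 40000 nM.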

Compound 4, half-maximal cytotoxic concentration: > 20000 nM
Compound 4 gave a limit, no number (the forecaster's own chance of this, stated with the estimate: 65%); the middle value lies on the limit itself.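

In this assay, among these compounds, compound 4 gives only a limit, as do compound 1, compound 2 and compound 3, so no step among them can be read. The compounds shown leave open whether cyclopentyl and isopropyl on a sulfur differ in toxicity at all.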